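A few compounds are considered here, and "the series" means these few. Any claim that something is new, unique, unknown or untested is made for them only; others in the source may bear on it.

Measured in a functional assay on MCF7 cells (Homo sapiens) for cytotoxicity, with a stated time of 48 h; on this read-out lower numbers stand for stronger inhibition and higher numbers for weaker inhibition:
- compound 1 `COc1cc(OC)c(C(=O)/C=C/c2ccccc2SC)c(OC)c1`: 9300 nM
- compound 2 `COc1cccc(/C=C/C(=O)c2c(OC)cc(OC)cc2OC)c1`: 9400 nM
- compound 3 `COc1cc(OC)c(C(=O)/C=C/c2ccccc2)c(OC)c1`: 9400 nM

Compound 3 stands level with compound 2 at the digits shown, and all three values lie within the scatter of one another, as a 1.0-fold higher number from compound 1 to compound 2 (0.00 log units; within the scatter) also shows.

Compound 4 `COc1cc(OC)c(C(=O)/C=C/c2ccc(Cl)cc2)c(OC)c1` has chloro in place of hydrogen on an aromatic carbon, para to a large group: chloro in place of hydrogen on an aromatic carbon.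

For the measured compounds named here, two measured steps bear on this change, as both exchange hydrogen for a group on the same aromatic ring: a 1.0-fold higher number from compound 1 to compound 3 (0.00 log units; within the scatter) and no change at the digits printed from compound 2 to compound 3 (within the scatter). Neither goes beyond the scatter. Going by the values given here, no measured compound carries chloro or has a group at this place, so the evidence is indirect and the range stays wide.

No step beyond the scatter is expected in this assay, and the estimate is a 1.2-fold lower number from compound 3 to compound 4 (0.07 log units; within the scatter). For compound 4 the estimated value is 8000 nM, with an expected range of 3000 nM to 20000 nM.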

Compound 4, half-maximal inhibitory concentration: 7500 nM
Compound 4: the middle estimate sits 1.1-fold (0.03 log units) above what was measured; measured number inside the range.
By their numbers in this assay, from the lowest: compounds 4, 1, 2 and 3 (each within the scatter of the next).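

In this assay, for the compounds shown here, chloro on the aromatic carbon para to a large group gives the first reading for a group at this place, a 1.3-fold lower number from compound 3 to compound 4 (0.10 log units; within the scatter), so the change from phenyl to 4-chlorophenyl does not separate the two compounds. The exchanges with the other substituted phenyl groups read the same way, with a 1.3-fold lower number from compound 2 to compound 4 (0.10 log units; within the scatter) and a 1.2-fold lower number from compound 1 to compound 4 (0.09 log units; within the scatter), which places 4-chlorophenyl alongside 3-methoxyphenyl and 2-(methylsulfanyl)phenyl in this assay. No measurement is available that would explain this result.

Going by these compounds, whether an amine or a carboxylic acid at this same place would give a step beyond the scatter remains open. Also open, on these data alone, is whether any change to the shared core, which stays constant across all four compounds, would move the number further than these phenyl exchanges do.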